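Trimming an Amide: From Piperidinyl to Methylamino

The source may hold more compounds than are shown below. What is called first, only, known or untested is meant among the compounds shown, and "the series" means these compounds.

Among the compounds with values here, compound 1 `CC(C)n1cc(-c2ccnc3[nH]c(C4CCN(CC(=O)N5CCCCC5)CC4)cc23)ccc1=O` was tested in an ADME assay on cells (Hepatocyte, Homo sapiens) for metabolic stability (a lower number here means slower removal, a higher number faster removal of the compound), and gives 8 uL/min, the lower of the two numbers measured so far, though only narrowly. Its nearest neighbour is compound 2 `COc1cc(F)ccc1-c1ccnc2[nH]c([C@H]3CC[C@H](NC(C)=O)CC3)cc12`, which in this assay gives 12 uL/min; the two values lie within the usual scatter of each other, so they cannot be told apart. Within the data shown here, no step between two measured compounds that differ in a single place has been recorded, so there is no measured step to lean on. Compound 3 `CNC(=O)CN1CCC(c2cc3c(-c4ccc(=O)n(C(C)C)c4)ccnc3[nH]2)CC1` is compound 1 with one change: methylamino in place of piperidin-1-yl on a carbonyl carbon. Among the measured compounds shown here, with only two measured values, and those close together, there is no basis for expecting this change to move the reading beyond the scatter in either direction. The step from compound 1 to compound 3 in this assay is therefore expected to be no change at the digits printed from compound 1 to compound 3 (within the scatter), none beyond the scatter. The estimate for compound 3 is 8 uL/min, with a range from 4 uL/min to 16 uL/min.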

Compound 3, intrinsic clearance in a liver preparation (reported as CLH), per the amount of preparation that the assay uses in the Hepatocyte assay: 1.7 uL/min
Compound 3: the middle estimate sits 4.7-fold (0.67 log units) above what was measured; measured number outside the range, below it.
By their numbers in the Hepatocyte assay, from the lowest: compound 3; then compounds 1 and 2 (each within the scatter of the next).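

Within the data shown here, in the Hepatocyte assay, methylamino in place of piperidin-1-yl on a carbonyl carbon gives a 4.7-fold lower number from compound 1 to compound 3 (0.67 log units; beyond the scatter), so the group at this position can change how fast the compound is removed, which the earlier compounds could not show. In a physicochemical assay for acid dissociation, compound 1 gives 7.8 and compound 3 gives 6.9. The change therefore also alters how readily a proton is given up, which may be linked to the slower removal, though a single pair cannot establish that link: the measured acid dissociation constant of compound 1, 7.8, and of compound 3, 6.9, a number 0.90 log units lower (beyond the scatter)

Going by these compounds, what remains open is whether the loss of the ring, the smaller size of the group or the new amide hydrogen accounts for these steps. Pyrrolidin-1-yl or dimethylamino on the same carbonyl carbon would help to separate these possibilities.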